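Side-chain variation on the bis-aziridinyl quinone carbamates

The source may report more compounds than this note shows. Statements on the series, on what has been measured and on what is new or still open speak of the compounds shown alone.

Measured compounds:
compound 1 `CCOC(COC(N)=O)C1=C(N2CC2)C(=O)C(C)=C(N2CC2)C1=O` — 6.18
compound 2 `CCC(COC(N)=O)C1=C(N2CC2)C(=O)C(C)=C(N2CC2)C1=O` — 6.18

Both measured compounds carry the same core and the same carbamate-bearing chain; they differ only in the group on the saturated chain carbon bound to a double-bonded ring carbon and a saturated chain carbon. In a functional assay on L1210 cells (Mus musculus), with a stated time of 12 days (on this read-out higher numbers stand for higher potency (the scale is a negative logarithm) and lower numbers for lower potency), compound 1 gives 6.18 and compound 2 gives 6.18; the step of no change at the digits printed from compound 1 to compound 2 (within the scatter) shows that exchanging ethoxy for ethyl at this position leaves the read-out unchanged within the scatter. Compound 2 therefore stands level with compound 1.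

Compound 3 `COCCOC(COC(N)=O)C1=C(N2CC2)C(=O)C(C)=C(N2CC2)C1=O` has not yet been measured in this assay. It differs from compound 2 by 2-methoxyethoxy in place of ethyl on a saturated chain carbon bound to a double-bonded ring carbon and a saturated chain carbon. Within the data shown here, the only step that bears on this is the one from compound 1 to compound 2, which was flat, and it concerns the same position. A return to an alkoxy group, now with two acceptors, is therefore expected to give at most a small change, a number 0.08 log units lower from compound 2 to compound 3 (within the scatter), in either direction. Compound 3 is estimated at 6.1, within 5.6 to 6.6.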

Compound 3, logarithm of the reciprocal of the active concentration, log(1/C): 6.03
Compound 3: the middle estimate sits 0.07 log units above what was measured; the measured number falls inside the stated range.
By their numbers in this assay, from the lowest: compounds 3, 1 and 2 (each within the scatter of the next).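

In this assay the position also accepts the longer 2-methoxyethoxy, with a number 0.15 log units lower from compound 2 to compound 3 (within the scatter) against ethyl. Extending the ethoxy of compound 1 by a terminal methoxy gives a number 0.15 log units lower from compound 1 to compound 3 (within the scatter) and so also stays within the scatter, which means that all three groups at this saturated chain carbon, alkyl or alkoxy, short or longer, read alike across these compounds. No measurement here offers an explanation for this flat behaviour.

Going by these compounds, whether the flat read-out would hold with an amine, a carboxylic acid or a phenyl ring at this position stays open. On these data alone, all three compounds share the core and the carbamate, so the effect of any change at those places also remains unknown.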